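Methoxy added on the aromatic carbon of compound 1

The source may hold more compounds than are shown below. What is called first, only, known or untested is meant among the compounds shown, and "the series" means these compounds.

Going by the values given here, compound 1 `COc1ccc(C(=O)/C=C/c2cc(-c3cc(OC)c(OC)c(OC)c3)n[nH]2)cc1OC` gives 89% in a functional assay on MCF7 cells (Homo sapiens) for cytotoxicity, read by sulforhodamine B assay, with a stated time of 48 h, tested at 0.01 uM (a lower number here means a stronger effect, a higher number a weaker effect of the compound at the concentration tested), the lowest of the two numbers measured so far. Compound 2 `COc1ccc(C(=O)/C=C/c2cc(-c3cc(OC)c(OC)c(OC)c3)n[nH]2)cc1` gives 101%; the step of a number 12 percentage points higher from compound 1 to compound 2 (beyond the scatter) shows that hydrogen in place of methoxy on an aromatic carbon weakens the effect by a modest amount beyond the scatter. Compound 3 `COc1cc(C(=O)/C=C/c2cc(-c3cc(OC)c(OC)c(OC)c3)n[nH]2)cc(OC)c1OC` goes the other way: methoxy in place of hydrogen on an aromatic carbon. Among the compounds with values here, only the step from compound 1 to compound 2 bears on this change, and it ran against a methoxy, so a modest lowering of the number is expected for compound 3 in this assay, a number 11 percentage points lower from compound 1 to compound 3 (beyond the scatter). Compound 3 is estimated at 78%, range 60% to 95%.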

Compound 3, a percentage reported as activity, at one concentration (the size of the read-out at that concentration, not a potency): 95%
Compound 3: the middle estimate sits 17 percentage points below what was measured; low and high end bracket the measured number.
By their numbers in this assay, from the lowest: compounds 1, 3 and 2 (each within the scatter of the next, the first and the last beyond it).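

Methoxy in place of hydrogen on this aromatic carbon, ortho to a methoxy group and meta to a large group, gives a number 6 percentage points higher from compound 1 to compound 3 (within the scatter) in this assay, so at this position the added group cannot be told apart from hydrogen. The earlier step, a number 12 percentage points higher from compound 1 to compound 2 (beyond the scatter), therefore does not carry over to this position.

As far as these compounds go, whether a hydroxyl, an amine or a longer chain on this carbon would move the number beyond the scatter remains open. No measurement on hand speaks to the reason for the difference between the two steps.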